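The source may report more compounds than this note shows. Statements on the series, on what has been measured and on what is new or still open speak of the compounds shown alone.

Compound 1 `COc1ccc(/C=C/c2nc(NCCN3CCCCC3)c3cc(Cl)ccc3n2)cc1OC`: 7640 nM
Compound 2 `O=[N+]([O-])c1ccc(/C=C/c2nc(NCCN3CCCCC3)c3ccccc3n2)cc1`: 36200 nM
Compound 3 `CC(C)N(CCNc1nc(/C=C/c2ccc([N+](=O)[O-])cc2)nc2ccc(Cl)cc12)C(C)C`: 56600 nM

All three numbers come from a functional assay on T-24 cells (Homo sapiens) for cytotoxicity, read by MTT assay, with stated times of 48 h and 4 h; a lower number here means a stronger inhibitor, a higher number a weaker inhibitor. Compound 3 stands level with compound 2, the two lying within the usual scatter of each other, while its number lies beyond the scatter above that of compound 1. The next compound to consider is the unmeasured compound 4 `O=[N+]([O-])c1ccc(/C=C/c2nc(NCCN3CCCCC3)c3cc(Cl)ccc3n2)cc1`, which differs from compound 3 in one place: piperidin-1-yl in place of diisopropylamino on a saturated chain carbon, two bonds along the chain from a nitrogen on an aromatic ring. In words, piperidin-1-yl takes the place of diisopropylamino on a saturated chain carbon, two bonds along the chain from a nitrogen on an aromatic ring. Going by the values given here, no measured pair shows this change on its own. Compound 2, at 36200 nM, and compound 1, at 7640 nM, both carry piperidin-1-yl, although each differs from compound 4 elsewhere. On that evidence, a small move in this assay toward a lower number is expected, one that may stay within the scatter. The expected size of this move is a 1.9-fold lower number from compound 3 to compound 4 (0.28 log units; within the scatter). For compound 4 the estimated value is 30000 nM, with an expected range from 12000 nM to 70000 nM.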

Compound 4, half-maximal inhibitory concentration: 34300 nM
Beside the measured number, compound 4's estimate is 1.1-fold (0.06 log units) below it; the range from low to high includes it.
By their numbers in this assay, from the lowest: compound 1; then compounds 4, 2 and 3 (each within the scatter of the next).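

In this assay, going by these compounds alone, piperidin-1-yl in place of diisopropylamino on the saturated chain carbon gives a 1.7-fold lower number from compound 3 to compound 4 (0.22 log units; within the scatter), the first reading of this change on its own, and the two amines stand level here. Chloro in place of hydrogen on an aromatic carbon gives a 1.1-fold lower number from compound 2 to compound 4 (0.02 log units; within the scatter), so this change also leaves the compounds level, whereas 4-nitrophenyl in place of 3,4-dimethoxyphenyl gives a 4.5-fold higher number from compound 1 to compound 4 (0.65 log units; beyond the scatter), the only one of these steps beyond the scatter. No measurement at hand explains any of these steps.

From the compounds shown here alone, whether a different amine at the chain end, such as morpholin-4-yl or dimethylamino, or a longer chain would also stay level remains open. So does whether diisopropylamino and piperidin-1-yl would stand level with 3,4-dimethoxyphenyl in place of 4-nitrophenyl.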